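The compounds below may be only part of what the source reports. "The series", "measured", "known", "first", "only" and "open" are said of these compounds alone.

In a functional assay on HOS cells (Homo sapiens) for antiproliferative activity, with a stated time of 72 h (on this read-out higher numbers stand for weaker inhibition and lower numbers for stronger inhibition), three compounds share one core and differ only in the group on a saturated chain carbon bound to a nitrogen on an aromatic ring: compound 1 (`Cc1ccc(CNc2ncnc3c2ncn3[C@@H]2O[C@H](CO)[C@@H](O)[C@H]2O)cc1`), compound 2 (`OC[C@H]1O[C@@H](n2cnc3c(NCc4ccc(Cl)c(Cl)c4)ncnc32)[C@H](O)[C@@H]1O`) and compound 3 (`OC[C@H]1O[C@@H](n2cnc3c(NCc4ccc(F)c(Cl)c4)ncnc32)[C@H](O)[C@@H]1O`). Compound 1 gives > 166000 nM as a limit. Compound 2 gives > 166000 nM as a limit. Compound 3 gives > 166000 nM as a limit and so has no exact number of its own. The whole series rests on the limit of > 166000 nM in this assay, at which 3 of the 3 values shown sit, and offers no ranking.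

Compound 4 (`OC[C@H]1O[C@@H](n2cnc3c(NCc4cccc(O)c4O)ncnc32)[C@H](O)[C@@H]1O`) makes one change to compound 3: 2,3-dihydroxyphenyl in place of 3-chloro-4-fluorophenyl on a saturated chain carbon bound to a nitrogen on an aromatic ring. The nearest measured steps are a step that the two limits leave unreadable from compound 1 to compound 3 and a step that the two limits leave unreadable from compound 2 to compound 3 and neither gives a size to carry over. Among the measured compounds shown here, no measured compound carries the 2,3-dihydroxyphenyl group, so the direction is uncertain. In this assay the expected outcome is little or no visible change, with a modest chance of stronger inhibition. The estimated move is an at least 1.3-fold lower number from compound 3 to compound 4 (0.14 log units; that floor lies within the scatter) and remains a rough expectation. For compound 4 the estimate is 120000 nM with an expected range from 15000 nM to 200000 nM overall.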

Compound 4, half-maximal inhibitory concentration: > 166000 nM
Compound 4: only a limit was reported (the forecaster's own chance of this, stated with the estimate: 60%); middle value at least 1.3-fold (0.14 log units) from the limit.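

Compound 4 also gives only a limit, so its steps from compound 1, compound 2 and compound 3 cannot be read, and the series still has no ranking: the limit of > 166000 nM in this assay, at which 4 of the 4 values shown sit. The compounds shown leave open whether any group at this place on the shared core would give an exact number in this assay.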